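The compounds below may be only part of what the source reports. "The series", "measured", "known", "first", "only" and "open" are said of these compounds alone.

Measured compounds:
Compound 1 `CCCSc1nc(N/N=C(\C)c2ccccc2O)c2nnn(Cc3ccccc3Cl)c2n1`, in a functional assay on MGC-803 cells (Homo sapiens) for antiproliferative activity, read by MTT assay, with a stated time of 72 h (on this read-out lower numbers stand for stronger inhibition and higher numbers for weaker inhibition), compound 1 gives 35000 nM.
Compound 2 `C#CCSc1nc(N/N=C/c2cc(OC)c(OC)c(OC)c2)c2nnn(Cc3ccccc3)c2n1`, in this assay compound 2 gives 4670 nM.
Compound 3 `CCCSc1nc(N/N=C/c2c[nH]c3ccccc23)c2nnn(Cc3ccccc3)c2n1`, in this assay compound 3 gives 7410 nM.

Among these three, compound 1 carries the highest number, and so the weakest inhibition, in this assay. Its nearest neighbour is compound 3, whose value sits beyond the scatter from that of compound 1, and compound 2 lies further still, also beyond the scatter. Compounds 2 and 3 differ from compound 1 in more than one place, so none of these gaps can be tied to a single structural change.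

Compound 4 `CCCSc1nc(N/N=C(\C)c2ccccc2O)c2nnn(Cc3ccccc3)c2n1` is not yet measured. It differs from compound 1 in one place: hydrogen in place of chloro on an aromatic carbon. Within the data shown here, no pair of measured compounds isolates this same change, so there is no direct precedent to lean on. On the evidence available, the step from compound 1 to compound 4 is expected to be small, with no clear direction, and most likely to remain within the scatter: a 1.1-fold higher number from compound 1 to compound 4 (0.06 log units; within the scatter). Compound 4 is therefore estimated at 40000 nM in this assay, with a plausible range from 15000 nM to 100000 nM.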

Compound 4, half-maximal inhibitory concentration: 2310 nM
Compound 4: the middle estimate sits 17-fold (1.24 log units) above what was measured; the whole stated range lies above it.
By their numbers in this assay, from the lowest: compound 4; then compounds 2 and 3 (each within the scatter of the next); then compound 1.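

In this assay, among these compounds, replacing the chloro with hydrogen, which turns 2-chlorobenzyl into benzyl, gives a 15-fold lower number from compound 1 to compound 4 (1.18 log units; beyond the scatter), a large step beyond the scatter and the first change in this set that can be read at a single place. It shows that this aromatic carbon, ortho to a large group, is not a silent position: with everything else in the molecule held the same, the compound with chloro there inhibits far more weakly than the compound with hydrogen. Nothing shown explains why this one change has so large an effect.

On these data alone, it remains open whether other groups at this place, such as fluoro, methyl or methoxy, would behave like chloro or like hydrogen, and whether chloro elsewhere on the same aromatic ring would have a comparable effect. As far as these compounds go, it is also open whether the step from 2-chlorobenzyl to benzyl would be as large with the rest of compound 2 or compound 3 in place of the rest of compound 4.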